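A few compounds are considered here, and "the series" means these few. Any claim that something is new, unique, unknown or untested is made for them only; others in the source may bear on it.

Of the compounds shown here, three sharing one core have been measured so far. In an ADME assay on HEK293 cells (Homo sapiens) for cytotoxicity, read by MTT assay, with a stated time of 48 h (a higher number here means a weaker inhibitor, a lower number a stronger inhibitor), compound 1 (`O=C1/C(=C\c2ccccc2)S/C(=N/c2ccccc2)N1Cc1ccncc1`) gives 64700 nM, compound 2 (`CC(C)c1ccc(/C=C2/S/C(=N/c3ccccc3)N(Cc3ccncc3)C2=O)cc1`) gives 137000 nM and compound 3 (`O=C1/C(=C\c2ccc(O)c(O)c2)S/C(=N/c2ccccc2)N1Cc1ccncc1`) gives 230000 nM. Compound 3 therefore sits with compound 2 at the weak end of this small set, with a 1.7-fold higher number from compound 2 to compound 3 (0.23 log units; within the scatter). Compound 1 lies apart, with a 3.6-fold higher number from compound 1 to compound 3 (0.55 log units; beyond the scatter).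

Compound 4 (`COc1ccc(OC)c(/C=C2/S/C(=N/c3ccccc3)N(Cc3ccncc3)C2=O)c1`) keeps the core and changes one group: 2,5-dimethoxyphenyl in place of 3,4-dihydroxyphenyl on a double-bonded chain carbon bound to a double-bonded ring carbon.

The two steps ending at compound 3 change this same group, and a third, a 2.1-fold higher number from compound 1 to compound 2 (0.33 log units; beyond the scatter), changes the same ring. All three are small, so in this assay this ring has so far moved the number only modestly. For the measured compounds named here, no measured compound carries a methoxy group, so the new group cannot be read directly from the data. A small shift towards a lower number is the likeliest outcome, and no shift beyond the scatter is expected. The estimated step is a 1.8-fold lower number from compound 3 to compound 4 (0.25 log units; within the scatter). For compound 4 the expected value is 130000 nM, with an estimated range from 55000 nM to 300000 nM.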

Compound 4, half-maximal inhibitory concentration: 80100 nM
For compound 4 the middle estimate is 1.6-fold (0.21 log units) above the measured one; measured number inside the range.
By their numbers in this assay, from the lowest: compounds 1, 4, 2 and 3 (each within the scatter of the next, the first and the last beyond it).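

Swapping 3,4-dihydroxyphenyl for 2,5-dimethoxyphenyl, on a double-bonded chain carbon bound to a double-bonded ring carbon, gives in this assay a 2.9-fold lower number from compound 3 to compound 4 (0.46 log units; beyond the scatter), which is as large as any step seen at this position so far. The enlarged group loses both hydrogen-bond donors and keeps both hydrogen-bond acceptors, yet it cannot be told apart from the plain phenyl or the 4-isopropylphenyl group, with a 1.2-fold higher number from compound 1 to compound 4 (0.09 log units; within the scatter) and a 1.7-fold lower number from compound 2 to compound 4 (0.23 log units; within the scatter). Two oxygen atoms on this ring therefore do not by themselves fix the number, since compound 3 and compound 4 both carry them and still differ beyond the scatter, although nothing measured here accounts for that difference.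

The swap changes the kind of oxygen group and its place on the ring at once, so the compounds shown cannot separate these two changes, which a 3,4-dimethoxyphenyl or a 2,5-dihydroxyphenyl group would help to do. From the compounds shown here alone, how this position would respond to an amine or a carboxylic acid on the ring also remains open.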